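The compounds below may be only part of what the source reports. "The series", "measured", "known", "first", "only" and "open" are said of these compounds alone.

Measured so far:
- Compound 1 `CCn1c(-c2cnc(C)nc2)nc2c(N[C@H]3CCN(C(=O)N4CC(OC)C4)C3)ncnc21`: 1.7 h
- Compound 2 `CCn1c(-c2ccc(C(F)(F)F)nc2)nc2c(O[C@H]3CCN(C(=O)[C@H]4C[C@@H](OC)C4)C3)ncnc21`: 2.6 h

In an ADME assay (Canis lupus familiaris, strain Beagle) for metabolic stability (on this read-out higher numbers stand for a longer-lived compound and lower numbers for a shorter-lived compound), compound 1 gives 1.7 h, and its value lies within the usual scatter of that of compound 2. Compound 3 `CCn1c(-c2cnc(C)nc2)nc2c(N[C@H]3CCN(C(=O)C4CC4)C3)ncnc21` departs from compound 1 in one place: cyclopropyl in place of 3-methoxyazetidin-1-yl on a carbonyl carbon. There, cyclopropyl stands in place of 3-methoxyazetidin-1-yl on a carbonyl carbon. Among the measured compounds shown here, no measured pair shows what a single change does here, so no step beyond the scatter is expected, in either direction. The expected change is a 1.1-fold lower number from compound 1 to compound 3 (0.05 log units; within the scatter). The estimate for compound 3 is 1.5 h, with an expected range from 0.8 h to 3 h.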

Compound 3, half-life: 4.7 h
Estimate against measurement, compound 3: 3.1-fold (0.50 log units) below; the measured number lies above the stated range.
By their numbers in this assay, from the lowest: compounds 1, 2 and 3 (each within the scatter of the next, the first and the last beyond it).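

In this assay, cyclopropyl in place of 3-methoxyazetidin-1-yl on a carbonyl carbon gives a 2.8-fold higher number from compound 1 to compound 3 (0.44 log units; beyond the scatter), and this step lies beyond the scatter. It is the first single change shown here, and it shows that the group on this carbonyl carbon can alter the half-life with the core of compound 1 held constant. No available measurement bears on what lies behind this step.

The compounds shown leave open whether azetidin-1-yl without its methoxy group, or cyclobutyl, would read like compound 1 or compound 3. They also leave open whether the step would recur on another core.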